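The source may hold more compounds than are shown below. What is called first, only, known or untested is meant among the compounds shown, and "the series" means these compounds.

Of the compounds shown here, two have been measured in an ADME assay on RAW264.7 cells (Mus musculus) for cytotoxicity, read by MTT assay, with a stated time of 72 h, tested at 100 uM; on this read-out lower numbers stand for a weaker effect and higher numbers for a stronger effect at the one concentration tested. Compound 1 `O=C(Cn1c(=O)oc2cc([N+](=O)[O-])ccc21)Nc1ccccn1` gives 47.3% in this assay. Compound 2 `O=C(Cn1c(=O)oc2cc(Cl)ccc21)NCc1ccco1` gives 50.3% in this assay. For the measured compounds named here, of the two numbers, the one for compound 2 is the upper one, but the gap to compound 1 lies within the usual scatter of this kind of measurement, so the two cannot be told apart.

Compound 3 `O=C(Cn1c(=O)oc2cc([N+](=O)[O-])ccc21)NCc1ccco1` has not yet been measured. It differs from compound 2 in one place: nitro in place of chloro on an aromatic carbon.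

The same nitro group already sits on the shared core of compound 1, which gives 47.3% in this assay, a value close to that of compound 2. The step of a number 2.3 percentage points lower from compound 2 to compound 3 (within the scatter) is therefore expected to stay within the scatter, with no clear movement in either direction. Compound 3 is estimated to give about 48% in this assay, within a range from 35% to 61%.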

Compound 3, a percentage reported as inhibition, at one concentration (the size of the read-out at that concentration, not a potency): 60.1%
The estimate for compound 3 lay 12.1 percentage points below the measured number; low and high end bracket the measured number.
By their numbers in this assay, from the lowest: compounds 1, 2 and 3 (each within the scatter of the next, the first and the last beyond it).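

In this assay, nitro in place of chloro on the aromatic carbon gives a number 9.8 percentage points higher from compound 2 to compound 3 (within the scatter), so this exchange at this position cannot be told apart from the ordinary spread of repeated measurements. With nitro held fixed on the shared core, (furan-2-yl)methyl in place of pyridin-2-yl on the amide-type nitrogen gives a number 12.8 percentage points higher from compound 1 to compound 3 (beyond the scatter), a modest step and the only one here that clears the scatter, which places the one clear movement on the amide side rather than on the aromatic carbon. Nothing measured here says why either step has the size it does.

On these data alone, how an amine or a methoxy group on the same aromatic carbon would read remains open. As far as these compounds go, it is also open whether the step on the amide-type nitrogen would hold with chloro on the core in place of nitro.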